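What Losing Heptyl Might Do to Compound 1

The source may report more compounds than this note shows. Statements on the series, on what has been measured and on what is new or still open speak of the compounds shown alone.

In a functional assay on PC-3 cells (Homo sapiens) for inhibition, read by MTT assay, with stated times of 18 h and 4 h (a lower number here means a stronger inhibitor, a higher number a weaker inhibitor), compound 1 `CCCCCCCCCCOP(=O)(O)OCCSC(=S)N1CCCCCC1` gives 32900 nM. Compound 3 `CCCCCCCCCCOP(=O)(O)OCCSC(=S)N1CCCCC1` gives 62500 nM, which is a 1.9-fold higher number from compound 1 to compound 3 (0.28 log units; within the scatter). Compound 2 `CCCCCCCCCCOP(=O)(O)OCCSC(=S)N1CCN(C)CC1` gives 80000 nM, which is a 2.4-fold higher number from compound 1 to compound 2 (0.39 log units; beyond the scatter). The remaining gap is a 1.3-fold lower number from compound 2 to compound 3 (0.11 log units; within the scatter). Compound 1 is therefore level with compound 3 and clear only of compound 2.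

Compound 4 `CCCOP(=O)(O)OCCSC(=S)N1CCCCCC1` keeps the azepan-1-yl group of compound 1 and alters the chain instead: hydrogen in place of heptyl on a saturated chain carbon, three bonds along the chain from an oxygen on an unsaturated carbon. All three measured steps swap only the group on the thiocarbonyl carbon, so none of them tests the chain. Going by the values given here, they show only that those swaps moved the number modestly, and no measured step covers a change like this one. The direction is therefore a judgement, but a clear move towards a higher number, meaning a weaker inhibitor, is expected in this assay. The estimated change is a 6.1-fold higher number from compound 1 to compound 4 (0.78 log units; beyond the scatter). For compound 4 the expected value is 200000 nM, with an estimated range of 70000 nM to 600000 nM.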

Compound 4, half-maximal inhibitory concentration: > 100000 nM
Compound 4 gave a limit, no number (the forecaster's own chance of this, stated with the estimate: 40%); the middle value lies beyond the limit too.
By their numbers in this assay, from the lowest: compounds 1, 3 and 2 (each within the scatter of the next, the first and the last beyond it). At a limit, above all of these: compound 4.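

In this assay compound 4 gives > 100000 nM, which is a limit of the assay and not a number. This is the first change shown in the chain rather than on the thiocarbonyl carbon, and hydrogen in place of heptyl gives an at least 3.0-fold higher number from compound 1 to compound 4 (0.48 log units; beyond the scatter), so the full size of the step stays unknown, though its direction is clear. The chain at this position therefore matters to the number in this assay, at least with azepan-1-yl on the thiocarbonyl carbon.

The compounds shown leave open how the number behaves at chain lengths between these two, or with a longer chain such as dodecyl. They also leave open whether a chain ending in an amine or a carboxylic acid would keep the number of compound 1.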